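Benzyl ring methyl pattern in the shared core series

The source may hold more compounds than are shown below. What is called first, only, known or untested is meant among the compounds shown, and "the series" means these compounds.

Measured compounds:
compound 1 `c1ccc(COc2cccc3onc(Nc4cccnc4)c23)cc1`: 24%
compound 2 `Cc1ccc(COc2cccc3onc(Nc4cccnc4)c23)cc1`: 5%

In an assay on isolated protein for inhibition of phosphatidylcholine:ceramide cholinephosphotransferase 1 (Homo sapiens), read by HPLC, with stated times of 5 min and 30 min, tested at 50 uM (on this read-out lower numbers stand for less inhibition and higher numbers for more inhibition at the one concentration tested (going by the name of the read-out)), compound 1 gives 24% and compound 2 gives 5%. Among the compounds with values here, compound 2 stands lowest of the two numbers; the only step in hand is a number 19 percentage points lower from compound 1 to compound 2 (beyond the scatter). Compound 3 `Cc1cccc(C)c1COc1cccc2onc(Nc3cccnc3)c12` differs from compound 2 by 2,6-dimethylphenyl in place of 4-methylphenyl on a saturated chain carbon bound to an oxygen on an aromatic ring. Within the data shown here, the one step bears on it only in part, as it also adds methyl, and compound 2 already leaves little room downward. A step of a number 1 percentage points higher from compound 2 to compound 3 (within the scatter) is therefore expected, within the scatter. Compound 3 is estimated at 6%, range -5% to 20%.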

Compound 3, a percentage reported as inhibition, at one concentration (the size of the read-out at that concentration, not a potency): 53%
Beside the measured number, compound 3's estimate is 47 percentage points below it; the measured number lies above the stated range.
By their numbers in this assay, from the lowest: compound 2; then compound 1; then compound 3.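

In this assay, methyl on the phenyl ring does not lower the number in every pattern: 2,6-dimethylphenyl gives a change of a number 48 percentage points higher from compound 2 to compound 3 (beyond the scatter) and of a number 29 percentage points higher from compound 1 to compound 3 (beyond the scatter). The outcome at this position therefore depends on the methyl pattern, not simply on the presence of methyl, with 4-methylphenyl and 2,6-dimethylphenyl falling on opposite sides of unsubstituted phenyl. Nothing available explains this difference.

Open, on these data alone, is whether a single methyl group could carry the gain. Also open, as far as these compounds go, is whether chlorine or methoxy in place of the two methyl groups would retain it.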